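Phenyl for fluoro on the chalcone ketone end

The compounds below may be only part of what the source reports. "The series", "measured", "known", "first", "only" and "open" are said of these compounds alone.

Measured compounds in a functional assay on A549 cells (Homo sapiens) for antiproliferative activity, read by MTT assay, with a stated time of 48 h; on this read-out higher numbers stand for weaker inhibition and lower numbers for stronger inhibition:
compound 1, `CCCCCCCCCCCCOc1ccc(C(=O)/C=C/c2c(/C=C/c3ccc(OC)cc3)cc(OC)cc2OC)cc1`, gives 7.9 ug/mL
compound 2, `COc1ccc(/C=C/c2cc(OC)cc(OC)c2/C=C/C(=O)c2ccc(F)cc2)cc1`, gives 6.6 ug/mL

Compound 2 has the lowest number of the two in this assay, with compound 1 nearest and within the usual scatter, so the two values are indistinguishable on this read-out and no order between them can be read. For the measured compounds named here, no step between measured compounds is available for the change considered here.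

Compound 3, `COc1ccc(/C=C/c2cc(OC)cc(OC)c2/C=C/C(=O)c2ccc(-c3ccccc3)cc2)cc1`, is not yet measured. It differs from compound 2 by phenyl in place of fluoro on an aromatic carbon. Since the two measured compounds give no guidance on this change, the step from compound 2 to compound 3 is expected to be a 1.1-fold lower number from compound 2 to compound 3 (0.04 log units; within the scatter), that is, none beyond the scatter in this assay. On that basis compound 3 is estimated at 6 ug/mL, with a range from 2 ug/mL to 15 ug/mL.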

Compound 3, half-maximal inhibitory concentration: 4.6 ug/mL
The estimate for compound 3 lay 1.3-fold (0.12 log units) above the measured number, within the range that was stated.
By their numbers in this assay, from the lowest: compounds 3, 2 and 1 (each within the scatter of the next).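

In this assay, phenyl in place of fluoro gives a 1.4-fold lower number from compound 2 to compound 3 (0.16 log units; within the scatter), the first step available at this position, para to a large group. It shows that a six-membered aromatic ring of carbon only can enter where a single fluorine leaves, turning 4-fluorophenyl into 4-phenylphenyl, without a difference that this read-out can separate. No evidence is available that would explain this result.

As far as these compounds go, it remains open whether an amine or a carboxylic acid at the same place would also stay within the scatter of these values, or would give a step beyond it. From the compounds shown here alone, a longer biaryl end carrying a hydroxyl group on the outer ring is likewise open, as is whether the step seen here would hold on a different core.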